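The source may report more compounds than this note shows. Statements on the series, on what has been measured and on what is new or still open speak of the compounds shown alone.

Measured so far in a functional assay on HepG2 cells (Homo sapiens) for antiproliferative activity, read by MTT assay, with a stated time of 24 h; a higher number here means a weaker inhibitor, a lower number a stronger inhibitor:
Compound 1 `COc1ccc(/C=C/C(=O)c2ccc(OC)c3c2OC(C)(C)C=C3)c(F)c1` gives 7560 nM.
Compound 2 `COc1ccc(C(=O)/C=C/c2cccc(F)c2)c2c1C=CC(C)(C)O2` gives > 10000 nM, which is a limit of this assay and not a number.
Compound 3 `COc1ccc(C(=O)/C=C/c2ccc3ccccc3n2)c2c1C=CC(C)(C)O2` gives 4280 nM.

Compound 2 therefore stands only as a limit, with no measured number of its own. The unmeasured compound 4 `COc1ccc(C(=O)/C=C/c2cccc([N+](=O)[O-])c2)c2c1C=CC(C)(C)O2` differs from it in one place: nitro in place of fluoro on an aromatic carbon. Among the compounds with values here, the only measured step that touches the same part of the shared core is an at least 1.3-fold higher number from compound 1 to compound 2 (0.12 log units; that floor lies within the scatter), a change of a different kind on the same ring, and it says little about a nitro group. Within the data shown here, no measured pair shows fluoro against nitro. The expectation for compound 4 is therefore a small step, if any, as an at least 1.1-fold lower number from compound 2 to compound 4 (0.04 log units; that floor lies within the scatter). Compound 4 is estimated at 9000 nM, within 3000 nM to 30000 nM.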

Compound 4, half-maximal inhibitory concentration: 2830 nM
Compound 4: the middle estimate sits 3.2-fold (0.50 log units) above what was measured, and the stated range ends above it.
By their numbers in this assay, from the lowest: compounds 4, 3 and 1 (each within the scatter of the next, the first and the last beyond it). At a limit, above all of these: compound 2.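

In this assay, nitro in place of fluoro on an aromatic carbon meta to a large group gives an at least 3.5-fold lower number from compound 2 to compound 4 (0.54 log units; beyond the scatter), so a single change at this position can move the number beyond the scatter, which the earlier step could not show. This size is only a floor, because compound 2 stands at a limit of the assay: the limit of > 10000 nM in this assay, at which 1 of the 4 values shown sits. The 3-nitrophenyl group also gives a 2.7-fold lower number from compound 1 to compound 4 (0.43 log units; beyond the scatter), measured against the 2-fluoro-4-methoxyphenyl group. Still open, from the compounds shown here alone, is whether another group on that carbon, such as an amine or a carboxylic acid, would give a lower number, and whether nitro would do the same on another carbon of the ring.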